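Aryl substituent changes and cytotoxicity in the series

The compounds below may be only part of what the source reports. "The series", "measured", "known", "first", "only" and "open" are said of these compounds alone.

Measured so far in an ADME assay on HOS cells (Homo sapiens) for cytotoxicity; a lower number here means that less compound is tolerated, a higher number that more compound is tolerated:
compound 1, `CN(Cc1nc2cccc(C(=O)NCCCCN)c2[nH]1)C1CCCc2cccnc21`: > 20000 nM, a limit of this assay
compound 2, `CN(Cc1nc2cccc(CCCN)c2[nH]1)C1CCCc2cccnc21`: 10000 nM
compound 3, `CN(Cc1nc2cccc(N3CCNCC3)c2[nH]1)C1CCCc2cccnc21`: > 20000 nM, a limit of this assay

Compound 1 stands only at a limit, not at a number, and (the limit of > 20000 nM in this assay, at which 2 of the 3 values shown sit). For the measured compounds named here, compound 2 is the one compound with a number. The step of an at least 2.0-fold lower number from compound 1 to compound 2 (0.30 log units; that floor lies within the scatter). The step of an at least 2.0-fold higher number from compound 2 to compound 3 (0.30 log units; that floor lies within the scatter), whereas a step that the two limits leave unreadable from compound 1 to compound 3.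

Compound 4, `CN1CCN(c2cccc3nc(CN(C)C4CCCc5cccnc54)[nH]c23)CC1`, differs from compound 1 in one place: 4-methylpiperazin-1-yl in place of (4-aminobutyl)carbamoyl on an aromatic carbon. The nearest measured steps are those with piperazin-1-yl on the same aromatic carbon: from compound 1 to compound 3 the two limits leave the step unreadable, and from compound 2 to compound 3 the number returns to the limit. Compound 4 is therefore expected to sit at or near the limit of this assay as well, and the step of a number no higher from compound 1 to compound 4 (the limit leaves the size open) is expected to be none beyond the scatter. Compound 4 is estimated at 20000 nM, between 8000 nM and 40000 nM.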

Compound 4, half-maximal cytotoxic concentration: 14000 nM
For compound 4 the middle estimate is 1.4-fold (0.15 log units) above the measured one; the measured number falls inside the stated range.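

In this assay compound 4 gives a number rather than a limit, so a substituted piperazine on this aromatic carbon can now be placed on a measured scale. Methyl in place of hydrogen on the amine nitrogen in the ring gives an at least 1.4-fold lower number from compound 3 to compound 4 (0.15 log units; that floor lies within the scatter), and 4-methylpiperazin-1-yl in place of (4-aminobutyl)carbamoyl gives an at least 1.4-fold lower number from compound 1 to compound 4 (0.15 log units; that floor lies within the scatter); neither floor shows a change beyond the scatter. 4-Methylpiperazin-1-yl in place of 3-aminopropyl gives a 1.4-fold higher number from compound 2 to compound 4 (0.15 log units; within the scatter), so the two groups with numbers are not separated in this assay.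

From the compounds shown here alone, compound 1 and compound 3 remain at a limit, so the full size of their steps stays open: the limit of > 20000 nM in this assay, at which 2 of the 4 values shown sit. Going by these compounds, whether an ethyl group on the ring nitrogen, or a carboxylic acid on this aromatic carbon, would move the number beyond the scatter also stays open.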